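Phenyl for indolyl: a step without a readable guide

The compounds below may be only part of what the source reports. "The series", "measured", "known", "first", "only" and "open" are said of these compounds alone.

In a physicochemical assay for solubility (a higher number here means a more soluble compound, a lower number a less soluble compound), compound 1 `CNC(=O)c1cc(C(=O)N[C@H]2[C@@H]3COC[C@@H]32)cc2c1OC[C@H]2c1cccnc1` gives >= 104 ug/mL, which is a limit of the assay. Compound 2 `CNC(=O)c1cc(C(=O)N[C@H]2[C@@H]3COC[C@@H]32)cc2c1OC[C@H]2c1cccc2[nH]ccc12` gives >= 171 ug/mL, also a limit and not a number, so its standing in the series cannot be ranked. Compound 3 `CNC(=O)c1cc(C(=O)N[C@H]2[C@@H]3COC[C@@H]32)cc2c1OC[C@H]2c1ccccc1` carries phenyl in place of 1H-indol-4-yl on a saturated ring carbon. Among the compounds with values here, one measured step bears on this change, at the same carbon: a step that the two limits leave unreadable from compound 1 to compound 2. Its size cannot be read, since both of its ends are limits, and it therefore gives no direction for this assay. The data support no expectation of a change beyond the scatter. The estimated step, an at least 1.1-fold lower number from compound 2 to compound 3 (0.05 log units; that floor lies within the scatter), is expected to carry no readable direction. For compound 3 the expected value is 150 ug/mL, with an estimated range of 60 ug/mL to 300 ug/mL.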

Compound 3, solubility: >= 165 ug/mL
Compound 3 gave a limit, no number; the forecaster's own chance of this, stated with the estimate: 55%; at least 1.1-fold (0.04 log units) between middle value and limit.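

In this assay compound 3 gives >= 165 ug/mL, which is a limit of the assay. Within the data shown here, compound 1, compound 2 and compound 3 all stand at limits, so no step among them can be read. The compounds shown leave open how pyridin-3-yl, 1H-indol-4-yl and phenyl rank in this assay.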